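The source may report more compounds than this note shows. Statements on the series, on what has been measured and on what is new or still open speak of the compounds shown alone.

In a functional assay on Bel7402/5-FU cells (Homo sapiens) for antiproliferative activity, read by MTT assay, with a stated time of 72 h (a lower number here means a stronger inhibitor, a higher number a weaker inhibitor), compound 1 `C=C1C(=O)O[C@H]2[C@H]1CC/C(COC(=O)Cn1cc(F)c(=O)n(Cc3ccc(Cl)cc3)c1=O)=C\CC[C@@]1(C)O[C@@H]21` gives 2420 nM and compound 2 `C=C1C(=O)O[C@H]2[C@H]1CC/C(COC(=O)Cn1cc(F)c(=O)n(Cc3ccc(C(F)(F)F)cc3)c1=O)=C\CC[C@@]1(C)O[C@@H]21` gives 2250 nM. These two numbers lie within the scatter of each other, so compound 2 stands level with compound 1 and no order can be read between them.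

Compound 3 `C=C1C(=O)O[C@H]2[C@H]1CC/C(COC(=O)Cn1cc(F)c(=O)n(Cc3ccccc3F)c1=O)=C\CC[C@@]1(C)O[C@@H]21` differs from compound 2 as follows: 2-fluorophenyl in place of 4-(trifluoromethyl)phenyl on a saturated chain carbon bound to an aromatic nitrogen. In words, 2-fluorophenyl stands in place of 4-(trifluoromethyl)phenyl on a saturated chain carbon bound to an aromatic nitrogen.

Among the compounds with values here, only one measured step bears on this change: a 1.1-fold lower number from compound 1 to compound 2 (0.03 log units; within the scatter), with trifluoromethyl in place of chloro on an aromatic carbon. Within the data shown here, it lies within the scatter, but it is only indirect evidence, since no measured compound carries 2-fluorophenyl. With that single step as a guide, no change beyond the scatter is expected in this assay, and the range is kept wide to reflect the thin evidence. The expected step is a 1.1-fold higher number from compound 2 to compound 3 (0.05 log units; within the scatter). For compound 3 the estimated value is 2500 nM, with an expected range of 1100 nM to 5500 nM.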

Compound 3, half-maximal inhibitory concentration: 3830 nM
The estimate for compound 3 lay 1.5-fold (0.19 log units) below the measured number, within the range that was stated.
By their numbers in this assay, from the lowest: compounds 2, 1 and 3 (each within the scatter of the next).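

In this assay, within the data shown here, the first change of the whole aryl group on a saturated chain carbon bound to an aromatic nitrogen, with 2-fluorophenyl (7 heavy atoms) in place of 4-(trifluoromethyl)phenyl (10 heavy atoms), gives a step within the scatter (a 1.7-fold higher number from compound 2 to compound 3 (0.23 log units; within the scatter)). The comparison with the chloro analogue, 2-fluorophenyl in place of 4-chlorophenyl, also stays within the scatter (a 1.6-fold higher number from compound 1 to compound 3 (0.20 log units; within the scatter)), so compounds 1, 2 and 3 form one level group, and neither swapping the substituent nor using a differently named fluorophenyl group separates them in this small set. No measurement is available to explain these numbers or to link them to any property of the groups.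

The compounds shown leave open whether the level result would hold for a group of a different kind on this aromatic ring, such as an amine or a carboxylic acid. They also do not settle what 4-fluorophenyl, unsubstituted phenyl or a longer chain between the aromatic nitrogen and the aryl ring would give, so the two substituent locations cannot yet be compared with the same group.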